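Fluoro-to-methyl exchange on the benzamide ring: working notes

The compounds below may be only part of what the source reports. "The series", "measured", "known", "first", "only" and "open" are said of these compounds alone.

Compound 1 `O=C(NCc1ccc(NC(=O)c2cccc(F)c2N2CCCC2)cc1)OCc1cccnc1`: in a functional assay on SGC-7901 cells (Homo sapiens) for inhibition, read by MTT assay, with a stated time of 72 h (a lower number here means a stronger inhibitor, a higher number a weaker inhibitor), compound 1 gives only a limit, > 100000 nM.
Compound 2 `O=C(NCc1ccc(NC(=O)c2ccc(F)cc2N2CCCC2)cc1)OCc1cccnc1`: compound 2 gives 56200 nM.
Compound 3 `Cc1cccc(C(=O)Nc2ccc(CNC(=O)OCc3cccnc3)cc2)c1N1CCCC1`: compound 3 gives only a limit, > 100000 nM.

Compound 1 and compound 2 have the same atoms joined differently; the difference between the two cores is not broken down here. Within the data shown here, compound 2 holds the only number in this assay, the other two values being limits, and the limit of > 100000 nM in this assay, at which 2 of the 3 values shown sit, is where those limits sit. From compound 1 to compound 3 the change is methyl in place of fluoro on an aromatic carbon, and a step that the two limits leave unreadable from compound 1 to compound 3.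

Compound 4 `Cc1ccc(C(=O)Nc2ccc(CNC(=O)OCc3cccnc3)cc2)c(N2CCCC2)c1` differs from compound 2 by methyl in place of fluoro on an aromatic carbon. The surroundings are not the same as in the earlier change: there the methyl enters ortho to a pyrrolidin-1-yl group and meta to a large group, here meta to a pyrrolidin-1-yl group and para to a large group, so this is the same kind of change, not the same.

No measured step sizes this exchange. The step from compound 2 to compound 4 is expected to be small, a 1.2-fold higher number from compound 2 to compound 4 (0.10 log units; within the scatter). That expectation rests on compound 2, which gives 56200 nM, and on the earlier step being unreadable. Compound 4 is estimated at 70000 nM, between 25000 nM and 200000 nM.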

Compound 4, half-maximal inhibitory concentration: 75200 nM
Beside the measured number, compound 4's estimate is 1.1-fold (0.03 log units) below it; the measured number falls inside the stated range.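

In this assay, on the core of compound 2, methyl in place of fluoro gives a 1.3-fold higher number from compound 2 to compound 4 (0.13 log units; within the scatter), so on this core the two groups cannot be told apart. This is one readable pair, with the exchange meta to a pyrrolidin-1-yl group and para to a large group, and it does not show that the result carries over to another core. On the core of compound 1 the same exchange cannot be read, since both ends of the step are limits of the assay and not numbers: the limit of > 100000 nM in this assay, at which 2 of the 4 values shown sit.

From the compounds shown here alone, it remains open whether a group other than fluoro or methyl at this place, such as an amine, a carboxylic acid or a longer chain, would move the number on the core of compound 2 beyond the scatter. Going by these compounds, it also remains open how the exchange would read in this assay on the core of compound 1 in a pair where both ends give numbers.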